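Swapping an aromatic tetrazole for a non-aromatic ring

The source may hold more compounds than are shown below. What is called first, only, known or untested is meant among the compounds shown, and "the series" means these compounds.

Three compounds share one core and differ only in the group on a saturated chain carbon bound to an aromatic carbon and a saturated chain carbon. Compound 1 `CC(C)C(c1ccc(-c2ccc3cccc(F)c3c2)[nH]c1=O)N1CCCCC1=O` carries 2-oxopiperidin-1-yl there, and in an assay on CHO cells for displacement of a labelled ligand from prostaglandin E2 receptor EP3 subtype (Homo sapiens), read by radioligand binding (on this read-out lower numbers stand for stronger inhibition and higher numbers for weaker inhibition), compound 1 gives 6.4 nM. Compound 2 `CC(C)C(c1ncc[nH]1)c1ccc(-c2ccc3cccc(F)c3c2)[nH]c1=O` carries 1H-imidazol-2-yl and gives 7.3 nM, a change of a 1.1-fold higher number from compound 1 to compound 2 (0.06 log units; within the scatter). Compound 3 `CC(C)C(Cc1nnn[nH]1)c1ccc(-c2ccc3cccc(F)c3c2)[nH]c1=O` carries (1H-tetrazol-5-yl)methyl and gives 34 nM, the highest of the three numbers; the steps to it were a 5.3-fold higher number from compound 1 to compound 3 (0.73 log units; beyond the scatter) and a 4.7-fold higher number from compound 2 to compound 3 (0.67 log units; beyond the scatter).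

Compound 4 `CC(C)C(/C=C1/CCNC1=O)c1ccc(-c2ccc3cccc(F)c3c2)[nH]c1=O` has not been measured. It differs from compound 3 by a group of 7 heavy atoms (5 carbon, 1 nitrogen, 1 oxygen; one five-membered non-aromatic ring with 1 hetero atom) in place of a group of 6 heavy atoms (2 carbon, 4 nitrogen; one five-membered aromatic ring with 4 hetero atoms), on a saturated chain carbon bound to an aromatic carbon and a saturated chain carbon. Among the compounds with values here, no measured step involves the entering group. Within the data shown here, the steps that bear on it are a 5.3-fold higher number from compound 1 to compound 3 (0.73 log units; beyond the scatter) and a 4.7-fold higher number from compound 2 to compound 3 (0.67 log units; beyond the scatter), which put the tetrazole-bearing compound 3 at the weak end of the series; compound 1, which carries 2-oxopiperidin-1-yl, gave 6.4 nM. Compound 4 is therefore expected to give a lower number than compound 3, an expected step of a 2.8-fold lower number from compound 3 to compound 4 (0.45 log units; beyond the scatter), since the new group is not identical to any already measured. The estimate for compound 4 is 12 nM, with a range from 4 nM to 40 nM.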

Compound 4, inhibition constant: 5.3 nM
Compound 4: middle estimate off by 2.3-fold (0.35 log units), on the high side; measured number inside the range.
By their numbers in this assay, from the lowest: compounds 4, 1 and 2 (each within the scatter of the next); then compound 3.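

In this assay the five-membered non-aromatic ring with its one hetero atom, taking the place of (1H-tetrazol-5-yl)methyl, gives a 6.4-fold lower number from compound 3 to compound 4 (0.81 log units; beyond the scatter) and so shows that the weak number of the tetrazole compound is not a limit of this position on the saturated chain carbon. The same group gives a 1.2-fold lower number from compound 1 to compound 4 (0.08 log units; within the scatter) and a 1.4-fold lower number from compound 2 to compound 4 (0.14 log units; within the scatter) in the same assay, so a five-membered lactam-type ring, a six-membered non-aromatic ring and an aromatic imidazole all sit within the scatter of one another, and only compound 3 stands apart among the four. Nothing measured on these groups explains why the tetrazole-bearing compound stands apart.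

Within the data shown here, compound 3 is the only one here with its ring carried on a methyl link, so a 1H-tetrazol-5-yl group sitting directly on the chain carbon would be needed to separate the effect of the ring from that of the link. On these data alone, how a carboxylic acid or an amine would fare at this place, and whether the ring of compound 4 keeps its number with a saturated link in place of the double bond, stays open.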